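The source may report more compounds than this note shows. Statements on the series, on what has been measured and on what is new or still open speak of the compounds shown alone.

Measured so far in a functional assay on MCF7 cells (Homo sapiens) for cytotoxicity, read by MTT assay, with a stated time of 48 h; on this read-out higher numbers stand for weaker inhibition and lower numbers for stronger inhibition:
- compound 1 `O=C(CSc1nnc(-c2ccncc2)o1)N/N=C/c1ccc(O)cc1`: 11700 nM
- compound 2 `Cc1ccc(/C=N/NC(=O)CSc2nnc(-c3ccncc3)o2)cc1`: 14700 nM
- compound 3 `O=C(CSc1nnc(-c2ccncc2)o1)N/N=C/c1cccc(C(F)(F)F)c1`: 14600 nM

Compound 1 gives the smallest of the three numbers in this assay, yet compound 2 and compound 3 both sit within the scatter of it, so the three cannot be told apart. Within the data shown here, the single step between neighbours, a 1.3-fold higher number from compound 1 to compound 2 (0.10 log units; within the scatter), also stays within the scatter. Compound 4 `O=C(CSc1nnc(-c2ccncc2)o1)N/N=C/c1ccccc1O` differs from compound 1 by 2-hydroxyphenyl in place of 4-hydroxyphenyl on a carbon with a double bond to nitrogen; the two share the same atoms, joined differently. Among the measured compounds shown here, no measured step changes where the hydroxy sits, so nothing bears on this change directly, and the one step available is flat. Compound 4 is therefore expected to stay roughly level with compound 1, a 1.0-fold higher number from compound 1 to compound 4 (0.01 log units; within the scatter). The estimate for compound 4 is 12000 nM, ranging from 5500 nM to 26000 nM.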

Compound 4, half-maximal inhibitory concentration: 4750 nM
Compound 4: middle estimate off by 2.5-fold (0.40 log units), on the high side; measured number outside the range, below it.
By their numbers in this assay, from the lowest: compound 4; then compounds 1, 3 and 2 (each within the scatter of the next).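

Where the hydroxy sits on this ring matters: in this assay, 2-hydroxyphenyl in place of 4-hydroxyphenyl gives a 2.5-fold lower number from compound 1 to compound 4 (0.39 log units; beyond the scatter) and is the first step here beyond the scatter. Against 4-methylphenyl, 2-hydroxyphenyl gives a 3.1-fold lower number from compound 2 to compound 4 (0.49 log units; beyond the scatter) even though 4-hydroxyphenyl and 4-methylphenyl stay within the scatter of each other, so at this place the hydroxy pays off only as 2-hydroxyphenyl among these compounds. Nothing available explains this difference. As far as these compounds go, whether 2-methylphenyl, 2-methoxyphenyl or 2-aminophenyl would match compound 4 stays open. So does whether the hydroxy itself is needed for the lower number.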